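The source may hold more compounds than are shown below. What is called first, only, known or untested is meant among the compounds shown, and "the series" means these compounds.

Measured compounds in a functional assay on HCT-116 cells (Homo sapiens) for antiproliferative activity, read by MTT assay, with a stated time of 48 h; on this read-out higher numbers stand for weaker inhibition and lower numbers for stronger inhibition:

Compound 1 `CS(=O)(=O)c1ccc(Nc2ncc(F)c(Nc3nc4ccccc4s3)n2)cc1` gives 3270 nM.
Compound 2 `CS(=O)(=O)c1ccc(Nc2ncc(F)c(Nc3nc4ccc(F)cc4s3)n2)cc1` gives only a limit of the assay, > 50000 nM.
Compound 3 `COc1ccc2nc(Nc3nc(Nc4ccc(S(N)(=O)=O)cc4)ncc3F)sc2c1` gives 11500 nM.

Compound 3 stands highest of the two numbers, and its nearest neighbour is compound 1. How the core of compound 3 differs from that of compound 2 is not broken down here. Between compound 2 and compound 1 the change is hydrogen in place of fluoro on an aromatic carbon, and it brings an at least 15-fold lower number from compound 2 to compound 1 (1.18 log units; beyond the scatter). That step is itself only a limit, since it rests on the limit of > 50000 nM in this assay, at which 1 of the 3 values shown sits, for compound 2.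

Compound 4 `COc1ccc2nc(Nc3ccnc(Nc4ccc(S(N)(=O)=O)cc4)n3)sc2c1` is not yet measured in this assay. It differs from compound 3 by hydrogen in place of fluoro on an aromatic carbon. This is the same kind of change as from compound 2 to compound 1, but not the same: there the place was an aromatic carbon of a six-membered aromatic ring of carbon only, part of a fused or bridged system of two rings, meta to a fused ring and para to a fused ring; here it is an aromatic carbon of a six-membered aromatic ring with 2 nitrogen, ortho to a large group, two atoms from the ring nitrogen and para to a large group. Going by the values given here, the one measured precedent points to a lower number, but its place is another, so only a modest step is expected, a 1.4-fold lower number from compound 3 to compound 4 (0.16 log units; within the scatter), with a wide range. Compound 4 is therefore estimated at 8000 nM, between 2000 nM and 40000 nM.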

Compound 4, half-maximal inhibitory concentration: 1480 nM
The estimate for compound 4 lay 5.4-fold (0.73 log units) above the measured number; the measured number lies below the stated range.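

In this assay, hydrogen in place of fluoro on an aromatic carbon gives a 7.8-fold lower number from compound 3 to compound 4 (0.89 log units; beyond the scatter), so the direction of the earlier step recurs on a second core, though at another place, on the six-membered aromatic ring with 2 nitrogen. The two steps set side by side read as follows: the same change on two cores in this assay, an at least 15-fold lower number (1.18 log units; beyond the scatter) from compound 2 to compound 1 and a 7.8-fold lower number (0.89 log units; beyond the scatter) from compound 3 to compound 4; the limit leaves it open whether they differ. Two pairs show a shared direction for this change at two different places on two different cores, but they do not show that its size carries over from one core to another, and the earlier step rests on a limit and not on a number: the limit of > 50000 nM in this assay, at which 1 of the 4 values shown sits.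

The compounds shown leave open whether the same change, made at the place on the six-membered aromatic ring with 2 nitrogen, would give a comparable step on the core of compound 1, which would separate the effect of the place from that of the core. Also open, from the compounds shown here alone, is whether a chloro, methyl or amino group at that place would stand with fluoro or with hydrogen in this assay series.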